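Olefin geometry swap in a macrocyclic stability series

The source may hold more compounds than are shown below. What is called first, only, known or untested is meant among the compounds shown, and "the series" means these compounds.

Measured so far:
compound 1, `C[C@@H](O)[C@H]1C(=O)N2C3=C(S[C@@H]4CN[C@@H](C4)C(=O)Nc4cccc(c4)C(=O)OC/C=C\COC3=O)[C@H](C)[C@H]12`: > 95%
compound 2, `Cc1oc(=O)oc1COC(=O)N1C[C@@H]2C[C@H]1C(=O)Nc1cccc(c1)C(=O)OC/C=C/COC(=O)C1=C(S2)[C@H](C)[C@@H]2[C@@H]([C@@H](C)O)C(=O)N12`: > 95%

In a physicochemical assay for metabolic stability, read by LC-MS, in phosphate buffer, with a stated time of 3 h, at pH 7.4, tested at 50 uM (a lower number here means that less of the compound is left, a higher number that more of the compound is left), compound 2 stands at > 95%, which is a limit of the assay and not a number. Compound 1 likewise sits at a limit, > 95%. Both shown values therefore rest on (the limit of > 95% in this assay, at which 2 of the 2 values shown sit). Compound 3, `Cc1oc(=O)oc1COC(=O)N1C[C@@H]2C[C@H]1C(=O)Nc1cccc(c1)C(=O)OC/C=C\COC(=O)C1=C(S2)[C@H](C)[C@@H]2[C@@H]([C@@H](C)O)C(=O)N12`, is not yet measured; it differs from compound 2 by the two compounds have the same atoms and bonds and differ only in configuration as drawn: 1 of 7 stereo elements differ; a double bond is drawn E in compound 2 and Z in compound 3. Within the data shown here, no step between measured compounds covers such a change. The expected step is a step that the limit leaves unreadable from compound 2 to compound 3, none beyond the scatter. For compound 3 the estimate is 97%, with a range from 90% to 100%, most probably again reported as a limit.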

Compound 3, percent of the compound remaining: > 95%
Compound 3: only a limit was reported (the forecaster's own chance of this, stated with the estimate: 85%); the middle value lies beyond the limit too.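

No step can be read from compound 2 to compound 3 or from compound 1 to compound 3, because each value is a limit and not a number: the limit of > 95% in this assay, at which 3 of the 3 values shown sit.

The compounds shown leave open whether the E or Z double bond, or the group on the amine nitrogen in a ring, changes the percent of compound remaining.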